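The source may report more compounds than this note shows. Statements on the series, on what has been measured and on what is new or still open speak of the compounds shown alone.

Going by the values given here, compound 2 `CC1=C(C(=O)OC2CCCCC2)C(c2ccoc2)NC(=O)N1` gives 1% in an assay on membranes from HeLa cells for displacement of a labelled ligand from adenosine receptor A3 (Homo sapiens), read by scintillation counting, with a stated time of 180 min, tested at 1 uM (on this read-out higher numbers stand for more inhibition at the one concentration tested (going by the name of the read-out) and lower numbers for less inhibition), and that is the lowest of the two numbers measured so far. Among the compounds with values here, the only other measured compound, compound 1 `CCN(CC)C(=O)C1=C(C)NC(=O)NC1c1ccoc1`, gives 37% in this assay. The two are alike apart from cyclohexyloxy in place of diethylamino on a carbonyl carbon, and that step, a number 36 percentage points lower from compound 1 to compound 2 (beyond the scatter), is large and well beyond the scatter.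

Compound 3 `CC1=C(C(=O)OCC2CC2)C(c2ccoc2)NC(=O)N1` has not yet been measured. It differs from compound 2 as follows: cyclopropylmethyl in place of cyclohexyl on an oxygen next to a carbonyl group. Both the cyclohexyl that leaves and the cyclopropylmethyl that enters are rings of carbon only, without hydrogen-bond donors or acceptors. Within the data shown here, no measured step touches this part of the molecule: the one known step, from compound 1 to compound 2, changes what sits on the carbonyl carbon, not what hangs from the oxygen. So there is nothing in the data to point to a direction, and the starting number of compound 2 is already at the bottom of the scale.

Compound 3 is therefore expected to stay close to compound 2, with a step of a number 4 percentage points higher from compound 2 to compound 3 (within the scatter) in this assay. The estimated value for compound 3 in this assay is 5%, with a range from -5% to 20%.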

Compound 3, a percentage reported as inhibition, at one concentration (the size of the read-out at that concentration, not a potency): 3%
The estimate for compound 3 lay 2 percentage points above the measured number; the measured number falls inside the stated range.
By their numbers in this assay, from the lowest: compounds 2 and 3 (each within the scatter of the next); then compound 1.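

In this assay, going by these compounds alone, the first change on the oxygen next to the carbonyl group gives a number 2 percentage points higher from compound 2 to compound 3 (within the scatter), so cyclopropylmethyl and cyclohexyl cannot be told apart here, even though they differ in ring size and in heavy-atom count. The large gap from the diethylamino compound also appears with this second group on the oxygen, as a number 34 percentage points lower from compound 1 to compound 3 (beyond the scatter). What rested on cyclohexyloxy alone now holds for cyclopropylmethoxy too, although these two oxygen-linked groups are still the only ones compared with diethylamino, and no measurement at hand gives a reason for either step.

The compounds shown leave open whether any group on this oxygen can bring the number near that of compound 1, since both groups tried are carbon rings and neither a short open chain such as ethyl nor a chain ending in an amine or a carboxylic acid appears among them. They also leave open how much of the higher number depends on diethylamino itself, as dimethylamino or piperidine on the carbonyl carbon would show.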